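Bromo for hydrogen on the phenyl: two matched pairs

A few compounds are considered here, and "the series" means these few. Any claim that something is new, unique, unknown or untested is made for them only; others in the source may bear on it.

Compound 1 `Cc1cc(O)c(C(=O)/C=C/c2ccc(OCc3ccccc3)cc2)c(-c2ccccc2)c1C(=O)/C=C/c1ccc(OCc2ccccc2)cc1` is the parent of the first pair. In a functional assay on MCF7 cells (Homo sapiens) for cytotoxicity, read by MTT assay, with a stated time of 24 h (a higher number here means a weaker inhibitor, a lower number a stronger inhibitor), compound 1 gives 10000 nM. Compound 2 `Cc1cc(O)c(C(=O)/C=C/c2ccc(OCc3ccccc3)cc2)c(-c2ccc(Br)cc2)c1C(=O)/C=C/c1ccc(OCc2ccccc2)cc1` carries the change bromo in place of hydrogen on an aromatic carbon relative to compound 1, and in this assay compound 2 gives 20000 nM. The step is a 2.0-fold higher number from compound 1 to compound 2 (0.30 log units; within the scatter), which is within the scatter, so the two values are to be read as level.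

Compound 3 `Cc1cc(O)c(C(=O)/C=C/c2ccc(Br)cc2)c(-c2ccccc2)c1C(=O)/C=C/c1ccc(Br)cc1` belongs to a second core; the difference between the two cores is not broken down here. In this assay compound 3 gives 10000 nM, which stands level with compound 1 at the digits printed and a step within the scatter away from compound 2.

Compound 4 `Cc1cc(O)c(C(=O)/C=C/c2ccc(Br)cc2)c(-c2ccc(Br)cc2)c1C(=O)/C=C/c1ccc(Br)cc1` has not been measured. It differs from compound 3 by bromo in place of hydrogen on an aromatic carbon. The place is the same word for word as in the first pair, so this is the same change. The step expected here is a 1.5-fold higher number from compound 3 to compound 4 (0.18 log units; within the scatter), essentially a repeat of the earlier step, because the matched step a 2.0-fold higher number from compound 1 to compound 2 (0.30 log units; within the scatter) stayed within the scatter. On that basis compound 4 is expected at about 15000 nM, with an estimated range from 6000 nM to 40000 nM.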

Compound 4, half-maximal inhibitory concentration: 15000 nM
The estimate for compound 4 equals the measured number at the digits printed; the measured number falls inside the stated range.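

In this assay, the new pair gives a 1.5-fold higher number from compound 3 to compound 4 (0.18 log units; within the scatter), so phenyl to 4-bromophenyl reads as level on the core of compound 3, as it did on the core of compound 1, and the two matched steps agree: the same change on two cores in this assay, a 2.0-fold higher number (0.30 log units; within the scatter) from compound 1 to compound 2 and a 1.5-fold higher number (0.18 log units; within the scatter) from compound 3 to compound 4, 1.3-fold (0.12 log units) apart, within the scatter of two such steps. For these two cores, then, the change carries over in the plain sense that it stays within the scatter on both. Among these compounds, this does not show that the bromo has any effect on cytotoxicity, and with only two pairs, neither with a step beyond the scatter, it cannot show how a change with a clear effect would carry over or whether this one would stay level on a further core.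

The compounds shown leave open whether another group at this place on the phenyl, such as an amine, a carboxylic acid or a longer chain, would move the value beyond the scatter. Also open, on these data alone, is what separates the two cores, since only bromo and benzyloxy groups appear on their side arms and a side-by-side reading of that difference is not available here.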